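Epimer of compound 2 in the microsomal clearance assay

A few compounds are considered here, and "the series" means these few. Any claim that something is new, unique, unknown or untested is made for them only; others in the source may bear on it.

Working notes on the series. The read-out throughout is an ADME assay on microsomes from liver (Homo sapiens) for metabolic stability, read by LC-MS, using NADPH, with stated times of 10 min and 45 min, tested at 1 uM; a lower number here means slower removal, a higher number faster removal of the compound. Compound 1 `COc1cc(C)[nH]c(=O)c1CN1CCc2c(Cl)cc([C@H](O)C3COC3)c(Cl)c2C1=O` is reported at < 8 uL/min, which is a limit of the assay and not a number (the limit of < 8 uL/min in this assay, at which 1 of the 3 values shown sits). Compound 3 `COc1cc(C)[nH]c(=O)c1CN1CCc2c(Cl)cc(C(OC)C3CCN(C(=O)CO)CC3)c(Cl)c2C1=O` has several entries, 12.6 uL/min; 25.6 uL/min (2 entries), so no single number stands for it (the several entries of compound 3 in this assay, 12.6 uL/min; 25.6 uL/min (2 entries)). Among the measured compounds shown here, compound 2 `Cc1cc(C)c(CN2CCc3c(Cl)cc([C@H](CO)[C@H]4CCCO4)c(Cl)c3C2=O)c(=O)[nH]1` gives 51.6 uL/min in this assay; this is the only single number among the three values shown.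

Compound 4 `Cc1cc(C)c(CN2CCc3c(Cl)cc([C@@H](CO)[C@H]4CCCO4)c(Cl)c3C2=O)c(=O)[nH]1` differs from compound 2 as follows: the two compounds have the same atoms and bonds and differ only in configuration as drawn: 1 of 2 stereo elements differ; a stereocentre at a saturated chain carbon is drawn R in compound 2 and S in compound 4. For the measured compounds named here, no step between measured compounds in this assay is available, so there is no measured guide for how a change of this kind moves the number. With the same atoms and bonds in both compounds, the expectation is that the step from compound 2 to compound 4 stays within the usual scatter of the assay, with no set direction: a 1.1-fold lower number from compound 2 to compound 4 (0.06 log units; within the scatter) is the expected step. Compound 4 is therefore expected to come out near 45 uL/min, with a likely range from 22 uL/min to 90 uL/min.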

Compound 4, intrinsic clearance in a liver preparation (reported as CLH), per the amount of preparation that the assay uses: 43 uL/min
The estimate for compound 4 lay 1.0-fold (0.02 log units) above the measured number; measured number inside the range.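

Among the compounds shown here, this pair gives the first step that can be read in this assay, and it isolates a single change: the stereocentre at a saturated chain carbon goes from R in compound 2 to S in compound 4, while the atoms, the bonds and the other stereo element stay as drawn. The result is a 1.2-fold lower number from compound 2 to compound 4 (0.08 log units; within the scatter), so for this pair the configuration at this carbon does not separate the two compounds in intrinsic clearance. The earlier compounds shown here could not show this, since compounds 1 and 3 each differ from compound 2 in more than one place and gave no step, and the finding applies to this pair alone.

The effect of the second stereo element remains open, as the compounds shown hold it fixed in this pair, and a single step gives no indication of whether configuration at this carbon would matter in the other compounds. Also unresolved is how the read-out would respond to an amine or a carboxylic acid at this saturated chain carbon.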